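The compounds below may be only part of what the source reports. "The series", "measured", "known", "first", "only" and "open" are said of these compounds alone.

Compound 1 `CN(C)c1ccc(C(=O)Nc2cccc(NC(=O)COc3ccc4c(c3)OCCO4)c2)cc1`: > 10000 nM
Compound 2 `Cc1ccc(C(=O)Nc2cccc(NC(=O)COc3ccc4c(=O)ccoc4c3)c2)cc1`: 22 nM

Within the data shown here, in an assay on isolated protein for inhibition of Rho-associated protein kinase 2 (Homo sapiens), read by scintillation counting, radiometric assay and 33P incorporation, with a stated time of 40 min, in the presence of a further agent that is not named here (a higher number here means a weaker inhibitor, a lower number a stronger inhibitor), compound 2 gives 22 nM, the only number among the two values shown. For compound 1 the assay reports only a limit, > 10000 nM, so the two compounds cannot be compared beyond that. The step to compound 3 `NCc1ccc(C(=O)Nc2cccc(NC(=O)COc3ccc4c(=O)ccoc4c3)c2)cc1` brings (amino in place of hydrogen on a saturated chain carbon bound to an aromatic carbon). Among the measured compounds shown here, with no measured step of this kind to lean on, the change is expected to move the readout little, if at all, beyond the usual scatter, with any shift expected towards a stronger inhibitor. Compound 3 is therefore estimated at 15 nM, ranging from 4 nM to 60 nM, a step of a 1.5-fold lower number from compound 2 to compound 3 (0.17 log units; within the scatter).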

Compound 3, half-maximal inhibitory concentration: 66 nM
Estimate against measurement, compound 3: 4.4-fold (0.64 log units) below; the whole stated range lies below it.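

Replacing methyl with aminomethyl gives a 3.0-fold higher number from compound 2 to compound 3 (0.48 log units; beyond the scatter) in this assay and so shows that the readout responds to a change at this place on the 4-methylphenyl group. The amino group is nevertheless accepted here: compound 3 gives 66 nM as a measured number and not a limit. From the compounds shown here alone, how a longer chain ending in an amine, or a carboxylic acid, would read at this place remains open. What lies behind the direction of this step also stays open, as nothing shown bears on it.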